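Swapping the heteroaryl group on the shared core

The source may report more compounds than this note shows. Statements on the series, on what has been measured and on what is new or still open speak of the compounds shown alone.

Measured so far, in an assay on isolated protein for antagonist activity at C-C chemokine receptor type 9 (Homo sapiens); a higher number here means a weaker inhibitor, a lower number a stronger inhibitor:
compound 1 `CC(C)(C)c1ccc(S(=O)(=O)Nc2ccc(Cl)cc2-c2nccc(CO)c2O)cc1` gives 330 nM
compound 2 `CC(C)(C)c1ccc(S(=O)(=O)Nc2ccc(Cl)cc2-c2nc(N)ncc2O)cc1` gives 30 nM

Among the compounds with values here, compound 2 has the lowest number of the two; the only other value, compound 1, lies an 11-fold lower number from compound 1 to compound 2 (1.04 log units; beyond the scatter) away. Compound 3 `CC(C)(C)c1ccc(S(=O)(=O)Nc2ccc(Cl)cc2-c2ncnc(CO)c2O)cc1` differs from compound 2 by a group of 9 heavy atoms (5 carbon, 2 nitrogen, 2 oxygen; one six-membered aromatic ring with 2 hetero atoms) in place of a group of 8 heavy atoms (4 carbon, 3 nitrogen, 1 oxygen; one six-membered aromatic ring with 2 hetero atoms), on an aromatic carbon. Within the data shown here, the one step that bears on this, from compound 1 to compound 2, was large and went with the reverse kind of change, so compound 3 is expected to give up part of that gain: a 5.0-fold higher number from compound 2 to compound 3 (0.70 log units; beyond the scatter) in this assay is estimated. For compound 3 the estimate is 150 nM, with a range from 50 nM to 500 nM.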

Compound 3, half-maximal inhibitory concentration: 325 nM
Estimate against measurement, compound 3: 2.2-fold (0.34 log units) below; the measured number falls inside the stated range.
By their numbers in this assay, from the lowest: compound 2; then compounds 3 and 1 (each within the scatter of the next).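

Compound 3 carries a ring with 2 hetero atoms, as compound 2 does, yet the data show an 11-fold higher number from compound 2 to compound 3 (1.03 log units; beyond the scatter) in this assay, so that count alone does not secure the low number of compound 2. Set against the ring with 1 hetero atom, the data show a 1.0-fold lower number from compound 1 to compound 3 (0.01 log units; within the scatter), so the added ring nitrogen makes no visible difference in this pair. Nothing measured here explains either step. Whether the amine of compound 2 itself accounts for its low number stays open. A methylamine or a carboxylic acid in place of that amine would test this.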